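Halide for Phenyl at the Benzyl Ring of a Sulfonamide

The source may report more compounds than this note shows. Statements on the series, on what has been measured and on what is new or still open speak of the compounds shown alone.

Among the measured compounds shown here, compound 2 `O=S(=O)(NCCCNCc1ccc(-c2ccccc2)cc1)c1cc(C(F)(F)F)cc(C(F)(F)F)c1` gives 2500 nM in a functional assay on PANC-1 cells (Homo sapiens) for inhibition, read by MTT assay, with a stated time of 72 h (on this read-out lower numbers stand for stronger inhibition of growth and higher numbers for weaker inhibition of growth), the highest of the two numbers so far; its nearest neighbour, compound 1 `O=S(=O)(NCCCNCc1ccc(Br)cc1)c1cc(C(F)(F)F)cc(C(F)(F)F)c1`, gives 2200 nM. For the measured compounds named here, the one measured step, a 1.1-fold higher number from compound 1 to compound 2 (0.06 log units; within the scatter), bears directly on the change to compound 3 `O=S(=O)(NCCCNCc1ccc(Cl)cc1)c1cc(C(F)(F)F)cc(C(F)(F)F)c1`, which is chloro in place of phenyl on an aromatic carbon. Since swapping bromo for phenyl moved the number only within the scatter, the reverse-type swap to chloro is expected to change little in this assay. Compound 3 is therefore estimated at 2300 nM, within 1100 nM to 4800 nM, a step of a 1.1-fold lower number from compound 2 to compound 3 (0.04 log units; within the scatter).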

Compound 3, concentration for 50% growth inhibition: 4900 nM
Compound 3: the middle estimate sits 2.1-fold (0.33 log units) below what was measured, and the stated range ends below it.
By their numbers in this assay, from the lowest: compounds 1, 2 and 3 (each within the scatter of the next, the first and the last beyond it).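

In this assay this position now separates two halides: chloro in place of bromo gives a 2.2-fold higher number from compound 1 to compound 3 (0.35 log units; beyond the scatter), a modest step and the first beyond the scatter. Chloro in place of phenyl, by contrast, gives a 2.0-fold higher number from compound 2 to compound 3 (0.29 log units; within the scatter), which stays within it, so the halide step is the only one here that can be read as a real difference. Nothing available explains why chloro and bromo part here.

Going by these compounds, whether fluoro or methoxy at this carbon would fall with chloro or with bromo remains open. So does whether a carboxylic acid or an amine would be tolerated there.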